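Removing one methoxy from compound 3: working notes

This account rests on a few compounds, and the source may have more. Where it says the series, first, only, none or still open, it means among the compounds named here.

Measured in a functional assay on SW-620 cells (Homo sapiens) for inhibition; on this read-out higher numbers stand for weaker inhibition and lower numbers for stronger inhibition:
- compound 1 `COc1cccc(C2NN=C(c3cc(OC)c(OC)c(OC)c3)C2O)c1`: 7350 nM
- compound 2 `COc1ccc(C2NN=C(c3cc(OC)c(OC)c(OC)c3)C2O)cc1`: 2670 nM
- compound 3 `COc1cc(C2=NNC(c3cc(OC)c(OC)c(OC)c3)C2O)cc(OC)c1OC`: 13600 nM

Compound 3 at 13600 nM lies within the scatter of compound 1 and beyond the scatter of compound 2, the lowest value. Compound 4 `COc1ccc(C2NN=C(c3cc(OC)c(OC)c(OC)c3)C2O)cc1OC` differs from compound 3 by hydrogen in place of methoxy on an aromatic carbon. Among the compounds with values here, the only measured step nearby is a 2.8-fold lower number from compound 1 to compound 2 (0.44 log units; beyond the scatter). It moves a methoxy rather than removing one, so it bears only indirectly. Compound 4 carries the methoxy groups of compound 1 and compound 2 on one ring, so a modest fall is expected in this assay. The expected change is a 2.5-fold lower number from compound 3 to compound 4 (0.39 log units; beyond the scatter). Compound 4 is estimated at 5500 nM, with an expected range of 2200 nM to 13000 nM.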

Compound 4, half-maximal inhibitory concentration: 8630 nM
For compound 4 the middle estimate is 1.6-fold (0.20 log units) below the measured one; low and high end bracket the measured number.
By their numbers in this assay, from the lowest: compound 2; then compounds 1, 4 and 3 (each within the scatter of the next).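

In this assay hydrogen in place of methoxy gives a 1.6-fold lower number from compound 3 to compound 4 (0.20 log units; within the scatter) and so does not separate the two compounds. Methoxy in place of hydrogen gives a 3.2-fold higher number from compound 2 to compound 4 (0.51 log units; beyond the scatter) yet only a 1.2-fold higher number from compound 1 to compound 4 (0.07 log units; within the scatter) on the other route, so the result of adding a methoxy depends on which methoxy the ring already carries. Nothing measured on these compounds explains that difference.

Still open, on these data alone, is whether a group other than methoxy or hydrogen at this position, such as an amine or a carboxylic acid, would move the number beyond the scatter of compound 3.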